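The source may hold more compounds than are shown below. What is called first, only, known or untested is meant among the compounds shown, and "the series" means these compounds.

Measured compounds:

Compound 1, `Nc1cccc(-c2cn3nc(-c4ccc(F)cc4)sc3n2)c1`: in a functional assay on CCRF-CEM cells (Homo sapiens) for inhibition, read by cell counting, with a stated time of 3 days (a lower number here means a stronger inhibitor, a higher number a weaker inhibitor), compound 1 gives >= 250000 nM, which is a limit of the assay and not a number.
Compound 2, `C=C(Br)C(=O)Nc1cccc(-c2cn3nc(-c4ccc(F)cc4)sc3n2)c1`: in this assay compound 2 gives 830 nM.

Compound 1 stands at the limit of the assay, where (the limit of >= 250000 nM in this assay, at which 1 of the 2 values shown sits); no measured number is known for it. For the measured compounds named here, the one measured step, an at least 300-fold lower number from compound 1 to compound 2 (2.47 log units; beyond the scatter), concerns the (1-bromoethenyl)carbonyl group on the ring nitrogen and says nothing about the fluorine at the other end of the molecule.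

Compound 3, `Nc1cccc(-c2cn3nc(-c4ccccc4)sc3n2)c1`, differs from compound 1 by hydrogen in place of fluoro on an aromatic carbon. Going by the values given here, no measured step touches this change, so there is no direct guide to its effect. Compound 1 sits at the limit and shows no measurable inhibition, and a small exchange of fluoro for hydrogen is expected to leave that picture unchanged; the step of a number no higher from compound 1 to compound 3 (the limit leaves the size open) is therefore expected to be no step beyond the scatter. Compound 3 is expected to give about 250000 nM, with a range from 50000 nM to 250000 nM, most probably reported again only as a limit.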

Compound 3, half-maximal inhibitory concentration: 33000 nM
For compound 3 the middle estimate is 7.6-fold (0.88 log units) above the measured one; the whole stated range lies above it.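

In this assay, the change from 4-fluorophenyl to phenyl gives an at least 7.5-fold lower number from compound 1 to compound 3 (0.87 log units; beyond the scatter), so this place on the ring is not silent: exchanging a single fluoro group for hydrogen is enough to bring a compound with the plain amine into the measurable range. Compound 3 gives 33000 nM, which shows that the shared core with the amine and no (1-bromoethenyl)carbonyl group can register inhibition in this test, although only with the phenyl group in place. The true size of the step remains unknown because compound 1 has a limit of the assay and not a number: the limit of >= 250000 nM in this assay, at which 1 of the 3 values shown sits.

The compounds shown do not reveal whether the same exchange would matter when the (1-bromoethenyl)carbonyl group sits on the nitrogen, as it does in compound 2. They also leave open how other groups at this place, such as chloro, methoxy or a nitrile, would compare with fluoro and hydrogen, and so whether hydrogen is unusually favourable here or fluoro is unusually unfavourable.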